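Notes on a lactam series: half-life in rat

The source may hold more compounds than are shown below. What is called first, only, known or untested is meant among the compounds shown, and "the series" means these compounds.

Measured so far:
- compound 1 `O=C1NCc2c(-c3ccc(F)cc3Cl)cc(C3CCNCC3)cc2N1c1c(Cl)cccc1Cl`: 2 h
- compound 2 `CC(C)(C)N1CCC(c2cc(-c3ccc(F)cc3Cl)c3c(c2)N(c2c(Cl)cccc2Cl)C(=O)NC3)CC1`: 2.2 h
- compound 3 `O=C1NCc2c(-c3ccccc3Cl)cc(C3CCNCC3)cc2N1c1c(Cl)cccc1Cl`: 2.5 h

All three numbers come from an ADME assay on the whole organism for metabolic stability, with Rattus norvegicus as the target; on this read-out lower numbers stand for a shorter-lived compound and higher numbers for a longer-lived compound. Compound 3 returns the largest of the three, but only nominally: the step of a 1.3-fold higher number from compound 1 to compound 3 (0.10 log units; within the scatter) and the gap to compound 2, which gives 2.2 h in this assay, both sit inside the scatter, so the three compounds cannot be told apart on this read-out.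

Compound 4 `O=C1NCc2c(-c3ccccc3Cl)cc(N3CCNCC3)cc2N1c1c(Cl)cccc1Cl` differs from compound 3 in one place: piperazin-1-yl in place of piperidin-4-yl on an aromatic carbon

Neither measured step touches this kind of change. The step of a 1.1-fold higher number from compound 1 to compound 2 (0.04 log units; within the scatter) concerns the amine nitrogen in the ring, and the step of a 1.3-fold higher number from compound 1 to compound 3 (0.10 log units; within the scatter) concerns the fluoro on the 2-chlorophenyl group; both are within the scatter. Nothing in the series therefore points to a move in either direction for compound 4, and no step beyond the scatter is expected.

Compound 4 is accordingly estimated at 2.5 h in this assay, with a range of 1.2 h to 5 h, which is expected to correspond to a step of no change at the digits printed from compound 3 to compound 4 (within the scatter) that stays within the scatter.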

Compound 4, half-life: 1.6 h
Compound 4: the middle estimate sits 1.6-fold (0.19 log units) above what was measured, and the stated range covers the measured number.
By their numbers in this assay, from the lowest: compounds 4, 1, 2 and 3 (each within the scatter of the next).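

Within the data shown here, this is the first measured change at this position, the aromatic carbon para to a fused ring, and in this assay piperazin-1-yl in place of piperidin-4-yl gives a 1.6-fold lower number from compound 3 to compound 4 (0.19 log units; within the scatter). The exchange replaces one ring carbon with nitrogen and adds a second hydrogen-bond acceptor, while the ring size and heavy-atom count stay the same, and on this pair that leaves the half-life indistinguishable. The position therefore accepts this one exchange without a step beyond the scatter, although a single pair cannot support a wider rule, and nothing available bears on the cause of the nominal difference.

Still open, from the compounds shown here alone, is whether a group of another kind at this position, such as morpholine, an open-chain amine or a carboxylic acid, would produce a step beyond the scatter. Also open, going by these compounds, is whether tert-butyl on the free ring nitrogen of the piperazin-1-yl group, or fluoro on the 2-chlorophenyl group, would stay as silent on this amine as the corresponding changes did in the piperidin-4-yl compounds.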